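Benzothiophene in Place of Fluorophenyl at the Amide

The source may hold more compounds than are shown below. What is called first, only, known or untested is meant among the compounds shown, and "the series" means these compounds.

Compound 1: `CC(C)[C@@H](NC(=O)c1ccc(F)cc1)C(=O)N1CCC(c2ccc(Cl)cc2)CC1`, 118 nM
Compound 2: `CC(C)C(NC(=O)c1ccc2ccccc2c1)C(=O)N1CCC(c2ccc(Cl)cc2)CC1`, 80 nM

Both compounds were tested in an assay on THP-1 cells for displacement of a labelled ligand from C-C chemokine receptor type 1 (Homo sapiens); a lower number here means a stronger inhibitor, a higher number a weaker inhibitor. The numbers for compound 1 and compound 2 differ by less than the usual scatter, so neither stands apart from the other. Compound 3, `CC(C)[C@@H](NC(=O)c1cc2ccccc2s1)C(=O)N1CCC(c2ccc(Cl)cc2)CC1`, is not yet measured. It differs from compound 1 by 1-benzothiophen-2-yl in place of 4-fluorophenyl on a carbonyl carbon. For the measured compounds named here, no measured pair shows this exact change, so the expected step of a 1.7-fold lower number from compound 1 to compound 3 (0.23 log units; within the scatter) is small and towards a lower number, perhaps not beyond the scatter. Compound 3 is expected to give 70 nM (range 30 nM to 200 nM) because compound 2, which also carries a two-ring group on the carbonyl carbon, gives 80 nM.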

Compound 3, half-maximal inhibitory concentration: 58 nM
Estimate against measurement, compound 3: 1.2-fold (0.08 log units) above; measured number inside the range.
By their numbers in this assay, from the lowest: compounds 3, 2 and 1 (each within the scatter of the next, the first and the last beyond it).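

In this assay, for the compounds shown here, 1-benzothiophen-2-yl in place of 4-fluorophenyl on a carbonyl carbon gives a 2.0-fold lower number from compound 1 to compound 3 (0.31 log units; beyond the scatter) and is the first step here to pass the usual scatter, though only modestly. This position therefore accepts a group of two fused aromatic rings containing sulfur, with no loss of binding. No measurement shown here explains the step. As far as these compounds go, it remains open whether the sulfur atom itself matters, which a comparison with a single thiophene ring could help test. Also open, from the compounds shown here alone, is how an amine or a carboxylic acid on the 1-benzothiophen-2-yl group would change the number.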